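Adding a methoxy group: from compound 1 to compound 3

The source may hold more compounds than are shown below. What is called first, only, known or untested is meant among the compounds shown, and "the series" means these compounds.

Measured so far:
compound 1 `COc1ccc(-c2cc(/C=C/C(=O)c3ccc(N)cc3)[nH]n2)cc1` — 4%
compound 2 `COc1cc(-c2cc(/C=C/C(=O)c3ccc(F)c(F)c3)[nH]n2)cc(OC)c1OC` — 2%

In a functional assay on K562 cells (Homo sapiens) for cytotoxicity, read by sulforhodamine B assay, with a stated time of 48 h, tested at 10 uM (a lower number here means a stronger effect, a higher number a weaker effect of the compound at the concentration tested), compound 1 gives 4% and compound 2 gives 2%. Compound 1 has the higher of the two numbers, but the gap to compound 2 lies within the scatter, so the two read-outs are not told apart.

Compound 3 `COc1ccc(-c2cc(/C=C/C(=O)c3ccc(N)cc3)[nH]n2)cc1OC` differs from compound 1 by methoxy in place of hydrogen on an aromatic carbon. Within the data shown here, no step between measured compounds bears on this change. Both measured values sit at the strong end, so the step is expected to stay within the scatter: a number 1 percentage points higher from compound 1 to compound 3 (within the scatter) is the estimated change. For compound 3 the expected value in this assay is 5%, within 0% to 18%.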

Compound 3, a percentage reported as activity, at one concentration (the size of the read-out at that concentration, not a potency): 3%
For compound 3 the middle estimate is 2 percentage points above the measured one; the range from low to high includes it.
By their numbers in this assay, from the lowest: compounds 2, 3 and 1 (each within the scatter of the next).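

In this assay, methoxy in place of hydrogen on an aromatic carbon, ortho to a methoxy group and meta to a large group, gives a number 1 percentage points lower from compound 1 to compound 3 (within the scatter). Among these compounds, this is the first direct reading at this position, and the added methoxy leaves compound 3 not told apart from compound 1. Nothing available gives a reason for this result.

On these data alone, with both compounds at the strong end of a single-concentration read-out, any difference in potency stays open. Also open, as far as these compounds go, is how a hydroxyl group, an amine or a longer alkoxy chain would read at this position.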